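The source may report more compounds than this note shows. Statements on the series, on what has been measured and on what is new or still open speak of the compounds shown alone.

Working notes on the series, where the shared core is held constant and only one oxygen substituent varies. In a functional assay on MDA-MB-231 cells (Homo sapiens) for antiproliferative activity, read by MTT assay, with a stated time of 72 h (a lower number here means a stronger inhibitor, a higher number a weaker inhibitor), compound 1 `CC1=CC[C@H]2[C@H](CC[C@]2(C)O)C(C)(C)[C@@H]1CC[C@H]1[C@]2(C)CC[C@H](OC(=O)c3ccc(Cl)cc3)C(C)(C)O[C@H]2CC[C@@]1(C)O` gives 10300 nM, compound 2 `CC1=CC[C@H]2[C@H](CC[C@]2(C)O)C(C)(C)[C@@H]1CC[C@H]1[C@]2(C)CC[C@H](OCc3ccccc3)C(C)(C)O[C@H]2CC[C@@]1(C)O` gives 29100 nM and compound 3 `CC1=CC[C@H]2[C@H](CC[C@]2(C)O)C(C)(C)[C@@H]1CC[C@H]1[C@]2(C)CC[C@H](OC(=O)NCc3ccccc3)C(C)(C)O[C@H]2CC[C@@]1(C)O` gives 40300 nM. Compound 3 is not separated from its nearest neighbour: a 1.4-fold higher number from compound 2 to compound 3 (0.14 log units; within the scatter). Its gap to the compound carrying 4-chlorophenyl on the carbonyl carbon is wider: a 3.9-fold higher number from compound 1 to compound 3 (0.59 log units; beyond the scatter).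

Compound 4 `CC1=CC[C@H]2[C@H](CC[C@]2(C)O)C(C)(C)[C@@H]1CC[C@H]1[C@]2(C)CC[C@H](OC(=O)c3ccc([N+](=O)[O-])cc3)C(C)(C)O[C@H]2CC[C@@]1(C)O` is the next case, with this change: 4-nitrophenyl in place of benzylamino on a carbonyl carbon. In words, 4-nitrophenyl replaces benzylamino on a carbonyl carbon. Among the compounds with values here, the most relevant measured step is the one that exchanges 4-chlorophenyl and benzylamino at that same place, the modest step of a 3.9-fold higher number from compound 1 to compound 3 (0.59 log units; beyond the scatter). Read in reverse, it points towards a lower number on leaving benzylamino. Within the data shown here, no measured compound carries 4-nitrophenyl, so its match to 4-chlorophenyl remains an assumption, and the range is kept wide. The expected step is a 3.4-fold lower number from compound 3 to compound 4 (0.53 log units; beyond the scatter), modest and towards a lower number. The estimate for compound 4 is 12000 nM, with an expected range of 5000 nM to 30000 nM.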

Compound 4, half-maximal inhibitory concentration: 8900 nM
Estimate against measurement, compound 4: 1.3-fold (0.13 log units) above; low and high end bracket the measured number.
By their numbers in this assay, from the lowest: compounds 4 and 1 (each within the scatter of the next); then compounds 2 and 3 (each within the scatter of the next).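

Nitro in place of chloro on an aromatic carbon does not separate this pair in this assay: a 1.2-fold lower number from compound 1 to compound 4 (0.06 log units; within the scatter). The aryl carbonyl position therefore accepts either of these two groups without a readable shift, which a single ester could not show. The gap to the other two groups now holds for a second aryl carbonyl group, in a 4.5-fold lower number from compound 3 to compound 4 (0.66 log units; beyond the scatter) and in a 3.3-fold lower number from compound 2 to compound 4 (0.51 log units; beyond the scatter), although nothing measured here bears on the reason for these steps.

Open, from the compounds shown here alone, is whether an amine or a carboxylic acid on that aromatic carbon would stay level with nitro and chloro. Also open, going by these compounds, is whether the aromatic ring is needed at all, which an acetyl group or a free hydroxyl on the same oxygen would test.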